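This account rests on a few compounds, and the source may have more. Where it says the series, first, only, none or still open, it means among the compounds named here.

Measured so far:
- compound 1 `Nc1cccc(-c2cn3nc(-c4cccs4)sc3n2)c1`: in a functional assay on HeLa cells (Homo sapiens) for inhibition, read by cell counting, with a stated time of 4 days (a lower number here means a stronger inhibitor, a higher number a weaker inhibitor), compound 1 reaches only the limit > 250000 nM, which marks the edge of the measurement rather than a number.
- compound 2 `CCc1ccc(-c2nn3cc(-c4cccc(N)c4)nc3s2)cc1`: compound 2 gives 8100 nM.
- compound 3 `CCOc1ccc(-c2nn3cc(-c4cccc(N)c4)nc3s2)cc1`: compound 3 gives 94000 nM.

Compound 3 therefore has the higher of the two real numbers, and its nearest neighbour is compound 2, the change being a 12-fold higher number from compound 2 to compound 3 (1.06 log units; beyond the scatter).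

Compound 4 `C=C(Br)C(=O)Nc1cccc(-c2cn3nc(-c4ccc(OCC)cc4)sc3n2)c1` differs from compound 3 in one place: (1-bromoethenyl)carbonyl in place of hydrogen on a nitrogen on an aromatic ring. Going by the values given here, no measured step touches this position; the only measured step, a 12-fold higher number from compound 2 to compound 3 (1.06 log units; beyond the scatter), swaps a group on the other end of the shared core and so offers no direct guide. Compound 1 sits at a limit and carries a different end group as well, so it cannot anchor this change either. With nothing measured along the amide direction, the expectation for compound 4 rests on the general uncertainty of an untested change, and the estimated step of a 9.4-fold lower number from compound 3 to compound 4 (0.97 log units; beyond the scatter) is given a wide range. For compound 4 the expected value in this assay is 10000 nM, between 1000 nM and 60000 nM.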

Compound 4, half-maximal inhibitory concentration: 1100 nM
Compound 4: middle estimate off by 9.1-fold (0.96 log units), on the high side, within the range that was stated.
By their numbers in this assay, from the lowest: compound 4; then compound 2; then compound 3. At a limit, above all of these: compound 1.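

Going by these compounds alone, compound 3 carries an amino group on the aromatic ring, and no earlier step tested any change at this nitrogen. In this assay, putting (1-bromoethenyl)carbonyl in place of the hydrogen on that nitrogen gives an 85-fold lower number from compound 3 to compound 4 (1.93 log units; beyond the scatter), so this position responds strongly and, in this pair, a free amino group is not needed for inhibition. Nothing shown explains why this change lowers the number so much.

The compounds shown do not separate the part played by the bromine from that of the carbonyl, so it stays open whether a plain acetyl group or an unbrominated propenoyl group on the same nitrogen would give a similar step. As far as these compounds go, it also stays open whether the same step would appear with the ethyl end group of compound 2 in place of the ethoxy group.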